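A trifluoromethyl added to compound 2: an expected outcome

The source may hold more compounds than are shown below. What is called first, only, known or untested is meant among the compounds shown, and "the series" means these compounds.

Compound 1 `NC(=O)c1c(NC(=O)c2ccccc2Cl)sc2c1CCN(Cc1c(Cl)cccc1Cl)C2`, compound 2 `NC(=O)c1c(NC(=O)c2ccccc2Cl)sc2c1CCN(C(=S)Nc1ccccc1)C2` and compound 3 `NC(=O)c1c(NC(=O)c2ccccc2Cl)sc2c1CCN(C(=O)Nc1ccccc1Cl)C2` share one core and differ only in the group carried on the amine nitrogen in a ring. In a functional assay on HL-60 cells (Homo sapiens) for antiproliferative activity, with a stated time of 24 h (on this read-out lower numbers stand for stronger inhibition and higher numbers for weaker inhibition), compound 1 gives 4850 nM, compound 2 gives 5940 nM and compound 3 gives 12500 nM. Compound 2 thus holds the second highest of the three numbers: the gap a 1.2-fold higher number from compound 1 to compound 2 (0.09 log units; within the scatter) is negligible, while a 2.1-fold higher number from compound 2 to compound 3 (0.32 log units; beyond the scatter) and a 2.6-fold higher number from compound 1 to compound 3 (0.41 log units; beyond the scatter) are modest. Compound 4 `NC(=O)c1c(NC(=O)c2ccccc2Cl)sc2c1CCN(C(=S)Nc1ccccc1C(F)(F)F)C2` carries trifluoromethyl in place of hydrogen on an aromatic carbon. No measured step alters a substituent on that phenyl; the steps shown all exchange the whole group on the ring nitrogen and are at most modest. Compound 4 is therefore expected to change little, a 1.2-fold lower number from compound 2 to compound 4 (0.07 log units; within the scatter), with an estimate of 5000 nM in this assay, ranging from 1800 nM to 14000 nM.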

Compound 4, half-maximal inhibitory concentration: 10600 nM
Beside the measured number, compound 4's estimate is 2.1-fold (0.33 log units) below it; low and high end bracket the measured number.
By their numbers in this assay, from the lowest: compounds 1, 2, 4 and 3 (each within the scatter of the next, the first and the last beyond it).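

In this assay, this is the first change shown on the phenyl itself rather than an exchange of the whole group on the ring nitrogen: trifluoromethyl in place of hydrogen, ortho to a large group, gives a 1.8-fold higher number from compound 2 to compound 4 (0.25 log units; within the scatter). A substituent of this size at this place therefore leaves the read-out within the scatter of the unsubstituted phenyl. Nothing available explains this result. The compounds shown leave open how a carboxylic acid, an amine or a methoxy group at this same place would read.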